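The source may hold more compounds than are shown below. What is called first, only, known or untested is meant among the compounds shown, and "the series" means these compounds.

Two compounds measured in a functional assay on U-87MG ATCC cells for antiproliferative activity against U-87 MG (Homo sapiens), read by MTT assay, with a stated time of 48 h, tested at 5 uM (on this read-out lower numbers stand for a stronger effect and higher numbers for a weaker effect at the one concentration tested), set the stage. Compound 1 `COc1ccc(-c2nc(SCC(=O)c3sc(-c4ccccc4)nc3C)nc(N)c2C#N)cc1` gives 68.8% in this assay, the lowest of the two numbers recorded; compound 2 `COc1ccc(-c2nc(C)c(C(=O)CSc3nc(-c4cccc(OC)c4)c(C#N)c(=O)[nH]3)s2)cc1` gives 71.3% in this assay, which lies within the scatter of compound 1, so the two cannot be told apart. Compound 3 `Cc1nc(-c2ccccc2)sc1C(=O)CSc1nc(N)c(C#N)c(-c2ccccc2)n1` has not yet been measured. It differs from compound 1 in one place: hydrogen in place of methoxy on an aromatic carbon. Cut one bond further out, the same change reads 4-methoxyphenyl to phenyl. Within the data shown here, no step between measured compounds exists here to guide the expectation, so the step from compound 1 is estimated from the small size of the change alone: the effect in this assay is expected to stay close, with a step of a number 4.2 percentage points higher from compound 1 to compound 3 (within the scatter) that may not exceed the scatter. For compound 3 the estimate in this assay is 73%, with a range from 52% to 92%.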

Compound 3, a percentage reported as activity, at one concentration (the size of the read-out at that concentration, not a potency): 103%
For compound 3 the middle estimate is 30 percentage points below the measured one; the whole stated range lies below it.
By their numbers in this assay, from the lowest: compounds 1 and 2 (each within the scatter of the next); then compound 3.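

In this assay, the step of a number 34.2 percentage points higher from compound 1 to compound 3 (beyond the scatter) shows a clearly weaker effect when the methoxy group of the 4-methoxyphenyl ring gives way to hydrogen. The earlier comparison could not show this, as compound 1 and compound 2 differ in more than one place, whereas this pair isolates one aromatic carbon, para to a large group, and shows that the group there matters even though only two heavy atoms leave. Nothing measured here explains why this change has so large an effect.

The compounds shown leave open whether the oxygen of the methoxy group is needed or whether another group on the same carbon would serve as well. A fluorine atom, a hydroxy group or a longer ethoxy group there would help to settle that question.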